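One More Methyl on an Oxazole-Bearing Core

The compounds below may be only part of what the source reports. "The series", "measured", "known", "first", "only" and "open" are said of these compounds alone.

Three compounds share a core and differ only in the aromatic group attached to it. Compound 2 `Cc1ccccc1-c1cccc(COc2ccc(S(=O)(=O)CC(=O)O)cc2)c1` carries a 2-methylphenyl group, compound 1 `Cc1cccc(C)c1-c1cccc(COc2ccc(S(=O)(=O)CC(=O)O)cc2)c1` a 2,6-dimethylphenyl group, and compound 3 `Cc1noc(C)c1-c1cccc(COc2ccc(S(=O)(=O)CC(=O)O)cc2)c1` a 3,5-dimethyl-1,2-oxazol-4-yl group. In a functional assay on CHO cells for agonist activity at Free fatty acid receptor 1 (Homo sapiens), read by FLIPR and calcium flux (on this read-out lower numbers stand for an effect already at smaller amounts and higher numbers for an effect only at larger amounts of compound), compound 2 gives 46.8 nM, compound 1 gives 66.1 nM, and compound 3 gives 269 nM.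

The difference between compound 2 and compound 1 is small: methyl in place of hydrogen on an aromatic carbon. It brought a 1.4-fold higher number from compound 2 to compound 1 (0.15 log units; within the scatter), so the two are indistinguishable in this assay. The difference between the two cores is larger: 3,5-dimethyl-1,2-oxazol-4-yl in place of 2-methylphenyl on an aromatic carbon. Here the outcome was a 5.7-fold higher number from compound 2 to compound 3 (0.76 log units; beyond the scatter) and, against the other methylated compound, a 4.1-fold higher number from compound 1 to compound 3 (0.61 log units; beyond the scatter).

Compound 4 `Cc1noc(C)c1-c1cccc(COc2ccc(S(=O)(=O)CC(=O)O)cc2)c1C` has not yet been measured in this assay. It differs from compound 3 by methyl in place of hydrogen on an aromatic carbon. Within the data shown here, this is the same kind of change as the one from compound 2 to compound 1, but not the same: in compound 1 the entering methyl sits ortho to a large group and meta to a methyl group, while in compound 4 it sits ortho to a 3,5-dimethyl-1,2-oxazol-4-yl group and ortho to a large group.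

The expected step is a 1.3-fold higher number from compound 3 to compound 4 (0.11 log units; within the scatter) because the earlier methyl gave only a 1.4-fold higher number from compound 2 to compound 1 (0.15 log units; within the scatter). Compound 4 is therefore estimated at 350 nM in this assay. Among the measured compounds shown here, the estimate for compound 4 spans from 150 nM to 850 nM, a wide band that reflects how little the single earlier example can say about a change made on a different core.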

Compound 4, half-maximal effective concentration: 363 nM
Compound 4: middle estimate off by 1.0-fold (0.02 log units), on the low side; the measured number falls inside the stated range.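

Adding the methyl to the core of compound 3 gave a 1.3-fold higher number from compound 3 to compound 4 (0.13 log units; within the scatter) in this assay, so compound 3 and compound 4 cannot be told apart there. Set beside the earlier case, the same change gives matching results on the two cores: the same change on two cores in this assay, a 1.4-fold higher number (0.15 log units; within the scatter) from compound 2 to compound 1 and a 1.3-fold higher number (0.13 log units; within the scatter) from compound 3 to compound 4, 1.0-fold (0.02 log units) apart, within the scatter of two such steps This supports carrying the change across these two cores in this assay as a step too small to read, but it rests on only two pairs, the methyl enters at a different place on each core, and it does not show that the same would hold on any other core or in any other kind of test.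

The compounds shown leave open whether a group larger than methyl on the same aromatic carbon, such as ethyl, methoxy or a longer chain, would also leave the number within the scatter. They also leave open whether an amine or a carboxylic acid at that place would do the same, and whether either core would respond to such a group as it does to methyl.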